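The source may report more compounds than this note shows. Statements on the series, on what has been measured and on what is new or still open speak of the compounds shown alone.

Compound 2 `CC#CCn1c(N2CCC[C@@H](N)C2)nc2c1c(=O)n(CCCN1CCN(c3nc(-c4ccccc4)ns3)CC1)c(=O)n2C` carries the shared core with a 3-phenyl-1,2,4-thiadiazol-5-yl group on an amine nitrogen in a ring. In a functional assay on HEK293 cells for agonist activity at Glucose-dependent insulinotropic receptor (Homo sapiens), read by a luciferase reporter (a higher number here means that more compound is needed for the effect, a lower number that less compound is needed), compound 2 gives 1930 nM, the higher of the two numbers recorded; its nearest neighbour is compound 1 `CC#CCn1c(N2CCC[C@@H](N)C2)nc2c1c(=O)n(CCCN1CCN(c3nc(-c4ccccc4)cs3)CC1)c(=O)n2C`, which in this assay gives 650 nM. For the measured compounds named here, the single recorded step is a 3.0-fold higher number from compound 1 to compound 2 (0.47 log units; beyond the scatter). Compound 3 `CC#CCn1c(N2CCC[C@@H](N)C2)nc2c1c(=O)n(CCCN1CCN(c3ncc(C(F)(F)F)cn3)CC1)c(=O)n2C` differs from compound 2 by 5-(trifluoromethyl)pyrimidin-2-yl in place of 3-phenyl-1,2,4-thiadiazol-5-yl on an amine nitrogen in a ring. Going by the values given here, no recorded step exchanges a 3-phenyl-1,2,4-thiadiazol-5-yl for a 5-(trifluoromethyl)pyrimidin-2-yl, so the step from compound 1 to compound 2 bears on it only as a sign that exchange at this ring nitrogen moves the number by a modest amount. The account therefore expects for compound 3 a step of a 1.3-fold lower number from compound 2 to compound 3 (0.11 log units; within the scatter) in this assay, small and of uncertain direction. The estimate for compound 3 in this assay is 1500 nM, with a range from 400 nM to 6000 nM.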

Compound 3, half-maximal effective concentration: 4020 nM
Beside the measured number, compound 3's estimate is 2.7-fold (0.43 log units) below it; low and high end bracket the measured number.
By their numbers in this assay, from the lowest: compound 1; then compound 2; then compound 3.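

Exchange at this amine nitrogen is not limited to five-membered rings: 5-(trifluoromethyl)pyrimidin-2-yl raises the number again in this assay (a 2.1-fold higher number from compound 2 to compound 3 (0.32 log units; beyond the scatter)) and gives the largest step among the three compounds (a 6.2-fold higher number from compound 1 to compound 3 (0.79 log units; beyond the scatter)). For the compounds shown here, the two groups that carry a phenyl ring, 4-phenyl-1,3-thiazol-2-yl and 3-phenyl-1,2,4-thiadiazol-5-yl, both give lower numbers than the single-ring group with trifluoromethyl, and no compound here goes against that order. No measurement is at hand to explain the order.

This change swaps the ring and removes the phenyl while adding the trifluoromethyl, so the compounds shown cannot assign the rise to any one of these. A pyrimidin-2-yl carrying a phenyl ring, or an unsubstituted pyrimidin-2-yl, would be needed to separate them.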